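A few compounds are considered here, and "the series" means these few. Any claim that something is new, unique, unknown or untested is made for them only; others in the source may bear on it.

Three compounds share one core and differ only in the aryl group on the carbon with a double bond to nitrogen. Compound 1 `COc1cc2c(Oc3ccc(NC(=O)N/N=C/c4ccc(O)cc4)cc3F)ccnc2cc1OCCCN1CCCCC1` gives 780 nM in a functional assay on A549 cells (Homo sapiens) for cytotoxicity, read by MTT assay, with a stated time of 72 h; a higher number here means a weaker inhibitor, a lower number a stronger inhibitor. Compound 2 `COc1cc2c(Oc3ccc(NC(=O)N/N=C/c4ccncc4)cc3F)ccnc2cc1OCCCN1CCCCC1` gives 840 nM in this assay, and compound 3 `COc1cc2c(Oc3ccc(NC(=O)N/N=C/c4cccs4)cc3F)ccnc2cc1OCCCN1CCCCC1` gives 790 nM there. Compound 3 stands second highest of the three numbers, yet every step among them lies within the scatter: a 1.1-fold higher number from compound 1 to compound 2 (0.03 log units; within the scatter), a 1.0-fold higher number from compound 1 to compound 3 (0.01 log units; within the scatter) and a 1.1-fold lower number from compound 2 to compound 3 (0.03 log units; within the scatter). Compound 4 `COc1cc2c(Oc3ccc(NC(=S)N/N=C/c4ccccc4)cc3F)ccnc2cc1OCCCN1CCCCC1` is not yet measured. Relative to compound 3 it carries a group of 11 heavy atoms (8 carbon, 2 nitrogen, 1 sulfur; one six-membered aromatic ring of carbon only) in place of a group of 10 heavy atoms (6 carbon, 2 nitrogen, 1 oxygen, 1 sulfur; one five-membered aromatic ring with 1 hetero atom), on a nitrogen on an aromatic ring. The measured steps bear on only part of this change, namely the swap of the aromatic ring, which left this assay unmoved each time; the replacement of the carbonyl by a thiocarbonyl has no precedent among these compounds. With no step beyond the scatter to build on, the expected step of a 1.0-fold higher number from compound 3 to compound 4 (0.01 log units; within the scatter) from compound 3 to compound 4 is none beyond the scatter, with added uncertainty for the unprecedented part. Compound 4 is therefore estimated at 800 nM, within 300 nM to 2500 nM.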

Compound 4, half-maximal inhibitory concentration: 330 nM
Beside the measured number, compound 4's estimate is 2.4-fold (0.38 log units) above it, and the stated range covers the measured number.
By their numbers in this assay, from the lowest: compound 4; then compounds 1, 3 and 2 (each within the scatter of the next).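

The change on a nitrogen on an aromatic ring moves the number beyond the scatter in this assay with a 2.4-fold lower number from compound 3 to compound 4 (0.38 log units; beyond the scatter) and with a 2.5-fold lower number from compound 2 to compound 4 (0.41 log units; beyond the scatter) and with a 2.4-fold lower number from compound 1 to compound 4 (0.37 log units; beyond the scatter) in each comparison. This makes compound 4 the strongest inhibitor of the four, whereas swapping the aromatic ring with the carbonyl kept had left compounds 1, 2 and 3 within the scatter of one another. No measurement shown accounts for this gain in potency.

The compounds shown leave open how the step divides between the thiocarbonyl and the phenyl ring, as compound 4 alone carries either one. Also open, from the compounds shown here alone, is whether a thiocarbonyl compound bearing a 4-aminophenyl or a 4-carboxyphenyl group would give a number close to that of compound 4.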